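A Chain-End Swap on a Shared Quinone Core

This account rests on a few compounds, and the source may have more. Where it says the series, first, only, none or still open, it means among the compounds named here.

The study concerns three compounds built on one shared core. Compound 1 `CC(C)(C)OC(=O)N1CCN(C(=O)COC2=CC(=O)c3c(O)cccc3C2=O)CC1` carries a piperazine amide capped with a tert-butoxycarbonyl group; in a functional assay on COLO 205 cells (Homo sapiens) for antiproliferative activity (a higher number here means a weaker inhibitor, a lower number a stronger inhibitor), compound 1 gives 2300 nM. Compound 2 `O=C(O)CCCCCNC(=O)COC1=CC(=O)c2c(O)cccc2C1=O` carries instead a six-carbon chain ending in a carboxy group, but in this assay compound 2 stands at "not determined" (no result reported), so no number anchors it. Compound 3 `CC(C)(C)OC(=O)NCCCCCCNC(=O)COC1=CC(=O)c2c(O)cccc2C1=O` is the next member, yet to be measured in this assay.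

The change from compound 2 to compound 3 is ((tert-butoxycarbonyl)amino)methyl in place of carboxy on a saturated chain carbon, five bonds along the chain from an amide-type nitrogen. The chain and the amide linkage stay as they are; only the far end of the chain is exchanged.

For the measured compounds named here, no measured pair in this set shows what such a change does in this assay, and compound 2 offers no number to step from. Compound 1, the only measured reference, shares the tert-butoxycarbonyl-capped amine with compound 3 and sets a plain expectation: a step of modest size at most, in either direction, and quite possibly none beyond the scatter. Compound 3 is therefore expected to give about 2500 nM in this assay, within a range of 800 nM to 8000 nM.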

Compound 3, half-maximal inhibitory concentration: 1300 nM
Estimate against measurement, compound 3: 1.9-fold (0.28 log units) above; the measured number falls inside the stated range.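

Compound 2 has no number in this assay and compound 3 gives 1300 nM there, so no step can be read from compound 2 to compound 3. As far as these compounds go, what exchanging carboxy for ((tert-butoxycarbonyl)amino)methyl at the far end of the chain does to this activity stays open. No measurement shown here offers an explanation for the value of compound 3.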